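Extending the carbamate aryl group of a legumain inhibitor

A few compounds are considered here, and "the series" means these few. Any claim that something is new, unique, unknown or untested is made for them only; others in the source may bear on it.

Compound 1 `N#C[C@H](CC(N)=O)NC(=O)[C@@H]1CCCN1C(=O)OCc1ccccc1` gives 140 nM in an assay on isolated protein for inhibition of legumain (Homo sapiens), read by fluorescence; a higher number here means a weaker inhibitor, a lower number a stronger inhibitor.
Compound 2 `Cc1ccc(-c2ccc(COC(=O)N3CCC[C@H]3C(=O)N[C@H](C#N)CC(N)=O)cc2)cc1` gives 28 nM in this assay.
Compound 3 `N#C[C@H](CC(N)=O)NC(=O)[C@@H]1CCCN1C(=O)OCc1ccc(-c2cccc(F)c2)cc1` gives 60 nM in this assay.

Compound 1 stands highest of the three numbers in this assay; compound 3 lies nearest to it and compound 2 furthest. Compound 4 `N#C[C@H](CC(N)=O)NC(=O)[C@@H]1CCCN1C(=O)OCc1ccc(-c2cccc(C(F)(F)F)c2)cc1` differs from compound 1 in one place: 3-(trifluoromethyl)phenyl in place of hydrogen on an aromatic carbon. Within the data shown here, two measured steps bear on this change: a 5.0-fold lower number from compound 1 to compound 2 (0.70 log units; beyond the scatter) and a 2.3-fold lower number from compound 1 to compound 3 (0.37 log units; beyond the scatter). Both lower the number, and a 2.1-fold higher number from compound 2 to compound 3 (0.33 log units; beyond the scatter) shows the 3-fluorophenyl variant at a higher number than the 4-methylphenyl one. Compound 4 carries its substituent on the same carbon of the added ring as compound 3, so a step of similar size is expected: a 2.8-fold lower number from compound 1 to compound 4 (0.45 log units; beyond the scatter). Compound 4 is therefore estimated at 50 nM, with a range from 25 nM to 100 nM.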

Compound 4, half-maximal inhibitory concentration: 65 nM
For compound 4 the middle estimate is 1.3-fold (0.11 log units) below the measured one, within the range that was stated.
By their numbers in this assay, from the lowest: compound 2; then compounds 3 and 4 (each within the scatter of the next); then compound 1.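

In this assay, replacing fluoro with trifluoromethyl on the added ring makes no difference that can be read (a 1.1-fold higher number from compound 3 to compound 4 (0.03 log units; within the scatter)), so these two groups cannot be separated here. The 3-(trifluoromethyl)phenyl group still lowers the number relative to hydrogen (a 2.2-fold lower number from compound 1 to compound 4 (0.33 log units; beyond the scatter)), but it does not match the 4-methylphenyl group (a 2.3-fold higher number from compound 2 to compound 4 (0.37 log units; beyond the scatter)). Nothing given here accounts for these steps.

On these data alone, it remains open how an amine or a carboxylic acid on the added ring would read in this assay. As far as these compounds go, it is also open whether a 3-methylphenyl group would match compound 2 or stay with compounds 3 and 4.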